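Phenyl in place of hydrogen: cytotoxicity on Vero cells

The source may hold more compounds than are shown below. What is called first, only, known or untested is meant among the compounds shown, and "the series" means these compounds.

Compound 1 `OC1CN(Cc2ccccc2)Cc2ccc(OCc3ccccc3)cc21`: 31800 nM
Compound 2 `OC1CN(Cc2ccccc2)Cc2ccc(OCc3ccc(-c4ccccc4)cc3)cc21`: 14800 nM
Compound 3 `CN1Cc2c(OCc3ccccc3)cccc2[C@@H](O)C1`: a limit only, > 100000 nM

All three were tested in an ADME assay on Vero cells (Chlorocebus sabaeus) for cytotoxicity, read by sulforhodamine B assay, with a stated time of 72 h; on this read-out higher numbers stand for weaker inhibition and lower numbers for stronger inhibition. Compound 1 gives 31800 nM and compound 2 gives 14800 nM. Compound 2 differs from compound 1 by phenyl in place of hydrogen on an aromatic carbon, and this change brought a 2.1-fold lower number from compound 1 to compound 2 (0.33 log units; beyond the scatter). Compound 3 gives no number, only a limit of this assay, > 100000 nM. That is the limit of > 100000 nM in this assay, at which 1 of the 3 values shown sits.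

Compound 4 `CN1Cc2c(OCc3ccc(-c4ccccc4)cc3)cccc2[C@@H](O)C1` has not been measured. It differs from compound 3 by phenyl in place of hydrogen on an aromatic carbon, the same change, at the same place, as from compound 1 to compound 2. The difference between the cores of compound 1 and compound 3 is not broken down here.

Since the same change gave a 2.1-fold lower number from compound 1 to compound 2 (0.33 log units; beyond the scatter), a step of similar size is expected from compound 3 to compound 4, so compound 4 is expected to move off the limit to a measurable number. The expected step is an at least 1.8-fold lower number from compound 3 to compound 4 (0.25 log units; that floor lies within the scatter), with the caution that the starting point is only a limit, so the true size cannot be known. Compound 4 is therefore estimated at 55000 nM, with a likely range from 20000 nM to 100000 nM.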

Compound 4, half-maximal inhibitory concentration: > 50000 nM
Compound 4: a limit, no number (the forecaster's own chance of this, stated with the estimate: 40%); the middle value is on the limit's open side.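

In this assay compound 3 and compound 4 both give only limits, not numbers, and the step between these two compounds cannot be read. On these data alone, it stays open whether phenyl in place of hydrogen on an aromatic carbon lowers the number on the core of compound 3, as it does from compound 1 to compound 2.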